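Moving the Fluorine: From Compound 3 to Compound 4

The source may hold more compounds than are shown below. What is called first, only, known or untested is meant among the compounds shown, and "the series" means these compounds.

Three compounds have been measured in an ADME assay on microsomes from liver (Mus musculus) for metabolic stability, read by LC-MS, using NADPH; a lower number here means that the compound disappears faster, a higher number that the compound lasts longer:
Compound 1 `Cc1cccnc1Nc1ncc(-c2ccccn2)o1` gives 0.0233 h.
Compound 2 `O=C(O)c1cccc(-c2csc(Nc3ccc(F)cc3)n2)c1` gives 0.635 h.
Compound 3 `COC(=O)c1cccc(-c2cnc(Nc3cccc(F)c3)o2)c1` gives < 0.0167 h.

For compound 3 that figure is a limit of the assay rather than a number, as the limit of < 0.0167 h in this assay, at which 1 of the 3 values shown sits, records. Compound 4 `COC(=O)c1cccc(-c2cnc(Nc3ccc(F)cc3)o2)c1` has not been measured; it differs from compound 3 by 4-fluorophenyl in place of 3-fluorophenyl on a nitrogen on an aromatic ring. Among the compounds with values here, no step between measured compounds covers this change, so compound 4 is expected to show no step beyond the usual scatter in this assay, with compound 3 still sitting at the limit. On that basis, compound 4 is estimated at 0.02 h, within a range of 0.0167 h to 0.05 h, an expected step of an at least 1.1-fold higher number from compound 3 to compound 4 (0.07 log units; that floor lies within the scatter).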

Compound 4, half-life: 0.0183 h
The estimate for compound 4 lay 1.1-fold (0.04 log units) above the measured number; the range from low to high includes it.
By their numbers in this assay, from the lowest: compounds 4 and 1 (each within the scatter of the next); then compound 2. At a limit, below all of these: compound 3.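

In this assay, 4-fluorophenyl in place of 3-fluorophenyl on a nitrogen on an aromatic ring gives an at least 1.0-fold higher number from compound 3 to compound 4 (0.03 log units; that floor lies within the scatter), the only step shown at this position, and it stays within the scatter. Compound 4 gives 0.0183 h, so with 4-fluorophenyl here the compound still disappears fast. Compound 3 stands at a limit of the assay, so the step is only a floor: the limit of < 0.0167 h in this assay, at which 1 of the 4 values shown sits.

On these data alone, what remains open is whether an amide or an amine in place of the methyl ester would change the half-life. As far as these compounds go, whether chlorine in place of the fluorine would do so is equally open.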